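Triazole nitrogen substituents on a flavanone core

The compounds below may be only part of what the source reports. "The series", "measured", "known", "first", "only" and "open" are said of these compounds alone.

Measured so far in a functional assay on RAW264.7 cells (Mus musculus) for inhibition, read by Griess assay, with stated times of 2 h and 24 h; on this read-out higher numbers stand for weaker inhibition and lower numbers for stronger inhibition:
Compound 1 `COc1ccc([C@@H]2CC(=O)c3c(O)cc(OCc4cn(C5CCCC5)nn4)cc3O2)cc1O` gives 10500 nM.
Compound 2 `COc1ccc([C@@H]2CC(=O)c3c(O)cc(OCc4cn(Cc5ccccc5C(F)(F)F)nn4)cc3O2)cc1O` gives 12500 nM.
Compound 3 `COc1ccc([C@@H]2CC(=O)c3c(O)cc(OCc4cn(Cc5cccc(C)c5)nn4)cc3O2)cc1O` gives 17400 nM.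

Compound 3 sits among the other two: a 1.7-fold higher number from compound 1 to compound 3 (0.22 log units; within the scatter) and a 1.4-fold higher number from compound 2 to compound 3 (0.14 log units; within the scatter), so no separation from either is established. The next entry, compound 4 `COc1ccc([C@@H]2CC(=O)c3c(O)cc(OCc4cn(Cc5cccc(C(F)(F)F)c5)nn4)cc3O2)cc1O`, differs from compound 3 only at the benzyl ring: trifluoromethyl in place of methyl on an aromatic carbon. Steps bearing on this change are those that reshape the group on the triazole nitrogen, a 1.2-fold higher number from compound 1 to compound 2 (0.08 log units; within the scatter) and a 1.4-fold higher number from compound 2 to compound 3 (0.14 log units; within the scatter), and both fall inside the scatter. Going by the values given here, no step here moves this assay beyond it, so compound 4 is expected to stay level with compound 3, a 1.2-fold lower number from compound 3 to compound 4 (0.06 log units; within the scatter). Compound 4 is accordingly estimated at 15000 nM, within 7000 nM to 32000 nM.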

Compound 4, half-maximal inhibitory concentration: 19900 nM
Compound 4: the middle estimate sits 1.3-fold (0.12 log units) below what was measured, and the stated range covers the measured number.
By their numbers in this assay, from the lowest: compounds 1, 2, 3 and 4 (each within the scatter of the next).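

In this assay, 3-(trifluoromethyl)benzyl in place of 3-methylbenzyl gives no separation (a 1.1-fold higher number from compound 3 to compound 4 (0.06 log units; within the scatter)). The trifluoromethyl position on the benzyl ring also establishes no separation (a 1.6-fold higher number from compound 2 to compound 4 (0.20 log units; within the scatter)), and neither does 3-(trifluoromethyl)benzyl in place of cyclopentyl (a 1.9-fold higher number from compound 1 to compound 4 (0.28 log units; within the scatter)), so even this widest step among the four compounds lies within the scatter. No evidence is available that bears on this result.

Still open, from the compounds shown here alone, is whether an amine or a carboxylic acid on the benzyl ring, or a longer chain on the triazole nitrogen, would move the number beyond the scatter.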